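Swapping a single stereocentre in a rice whole-organism screen

The source may report more compounds than this note shows. Statements on the series, on what has been measured and on what is new or still open speak of the compounds shown alone.

Two closely related ureas have been measured so far. Compound 1, `CC(C)c1ccccc1NC(=O)N[C@@H](C)c1ccccc1`, gives 96% in an ADME assay on the whole organism with Oryza sativa as the target, tested at 1 uM; on this read-out higher numbers stand for a weaker effect at the one concentration tested and lower numbers for a stronger effect. Compound 2, `C[C@@H](NC(=O)Nc1ccccc1C(C)(C)C)c1ccccc1`, gives 95% in this assay, the lower of the two numbers, though the gap to compound 1 falls inside the usual scatter of repeated runs, so the two readings cannot be told apart. Both numbers sit close to the top of the scale, which on this read-out means hardly any effect at the single concentration tested.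

The next compound, compound 3, `C[C@H](NC(=O)Nc1ccccc1C(C)(C)C)c1ccccc1`, has not yet been measured. Compared with compound 2 the change is the two compounds have the same atoms and bonds and differ only in configuration as drawn: 1 of 1 stereo elements differ; a stereocentre at a saturated chain carbon is drawn R in compound 2 and S in compound 3. Among the measured compounds shown here, no step between measured compounds is available to say how much such a swap matters here, so the expectation rests only on where compound 2 stands. Because compound 2 gives 95%, and the scale leaves little room to move upward, compound 3 is expected to land near the same region, with a step of about a number 3 percentage points lower from compound 2 to compound 3 (within the scatter) in this assay. The estimated value for compound 3 is 92%, with a plausible range from 75% to 100%.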

Compound 3, a percentage reported as activity, at one concentration (the size of the read-out at that concentration, not a potency): 99%
The estimate for compound 3 lay 7 percentage points below the measured number, and the stated range covers the measured number.
By their numbers in this assay, from the lowest: compounds 2, 1 and 3 (each within the scatter of the next).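

Inverting the single stereocentre at the saturated chain carbon, from R to S, gives a number 4 percentage points higher from compound 2 to compound 3 (within the scatter) in this assay. Among the compounds shown here, this is the first direct reading of that change at this position, and it shows no effect that can be separated from the ordinary spread of repeat measurements. Methyl in place of hydrogen on a saturated chain carbon bound to an aromatic carbon and two saturated chain carbons gives a number 3 percentage points higher from compound 1 to compound 3 (within the scatter), so this change also stays unresolved. The stereocentre comparison is the tightest one available, and what it isolates is simple: the fact that compounds 2 and 3 differ only in the configuration as drawn

All three compounds sit close to the top of the scale, where hardly any effect is seen at the one concentration tested, so these readings cannot show whether configuration would matter in a compound with a clearer effect. As far as these compounds go, it remains open whether an amine or a carboxylic acid on the shared core would bring the number down from this region, and whether the R and S forms would then separate.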